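Chloro to azetidin-1-yl on the pyridin-4-yl arm

The compounds below may be only part of what the source reports. "The series", "measured", "known", "first", "only" and "open" are said of these compounds alone.

Measured so far:
compound 1 `NS(=O)(=O)c1cccc(-c2nc(C(c3ccc(F)cc3)c3ccc(F)cc3)sc2CC(=O)O)c1`: 710 nM
compound 2 `O=C(O)Cc1sc(C(c2ccc(F)cc2)c2ccc(F)cc2)nc1-c1ccnc(Cl)c1`: 39 nM

Both numbers come from an in vitro functional assay on HEK285-7 cells for antagonist activity at prostaglandin D2 receptor 2 (Homo sapiens), read by BRET and beta-arrestin recruitment; on this read-out lower numbers stand for stronger inhibition and higher numbers for weaker inhibition. For the measured compounds named here, compound 2 holds the lowest of the two numbers; its nearest neighbour is compound 1, and the one step between them, an 18-fold lower number from compound 1 to compound 2 (1.26 log units; beyond the scatter), is large and beyond the scatter. That step swaps the whole aryl group on the shared core, so it says only that this arm matters, not how a substituent on the pyridine behaves.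

Compound 3 `O=C(O)Cc1sc(C(c2ccc(F)cc2)c2ccc(F)cc2)nc1-c1ccnc(N2CCC2)c1` is not yet measured. It differs from compound 2 by azetidin-1-yl in place of chloro on an aromatic carbon. Going by the values given here, no measured pair changes a group on the 2-chloropyridin-4-yl ring, so nothing bears directly on this step; the series gives no size for it. Given the sensitivity of this arm shown by compound 1 and compound 2, a step of modest size in either direction, or none beyond the scatter, is expected, with a slight lean toward a higher number.

For compound 3 the expected value is 60 nM, range 15 nM to 250 nM. That estimate corresponds to a 1.5-fold higher number from compound 2 to compound 3 (0.19 log units; within the scatter).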

Compound 3, half-maximal inhibitory concentration: > 100000 nM
Compound 3 was reported as a limit; the forecaster's own chance of this, stated with the estimate: 2%; middle value at least 1600-fold (3.22 log units) from the limit.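

In this assay compound 3 carries a limit of the read-out, not a number: the limit of > 100000 nM in this assay, at which 1 of the 3 values shown sits.

Azetidin-1-yl in place of chloro on the aromatic carbon next to the ring nitrogen gives an at least 2500-fold higher number from compound 2 to compound 3 (3.40 log units; beyond the scatter), so one substituent at this position can decide the read-out, whereas the earlier step between compounds changed the whole aryl arm. Against the 3-sulfamoylphenyl arm, the 2-(azetidin-1-yl)pyridin-4-yl arm gives an at least 140-fold higher number from compound 1 to compound 3 (2.14 log units; beyond the scatter), so the pyridine ring alone does not carry the gain seen with the 2-chloropyridin-4-yl arm.

Only chloro and azetidin-1-yl are shown at this position, so it stays open whether fluoro, methyl, methoxy or an open-chain dimethylamino group would hold the value of compound 2 or share the loss seen with compound 3. Without such neighbours, the loss cannot be tied to the four-membered ring of azetidin-1-yl, to its nitrogen on the pyridine, or to the removal of chloro itself.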